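Dialkylamino swap at the carbamate-bearing ring: cytotoxicity notes

The compounds below may be only part of what the source reports. "The series", "measured", "known", "first", "only" and "open" are said of these compounds alone.

Measured so far:
compound 1 `COc1ccc(C(=O)Nc2cc3nc(C4CCCCC4)[nH]c3cc2N(C)C)cc1` gives, as a limit of the assay, > 100 ug/mL in an ADME assay on Vero cells (Chlorocebus sabaeus) for cytotoxicity, read by resazurin assay, with a stated time of 3 days; on this read-out higher numbers stand for weaker inhibition and lower numbers for stronger inhibition
compound 2 `CCN(CC)c1cc2[nH]c(C3CCCCC3)nc2cc1NC(=O)OCC(F)(F)F` gives, as a limit of this assay, > 100 ug/mL

Compound 2 stands at the limit of this assay; its value is a limit, not a number. Compound 1 sits at the same limit, so that both values shown rest at the limit of > 100 ug/mL in this assay, at which 2 of the 2 values shown sit, and no ranking between the two compounds can be read from them. Within the data shown here, no step between measured compounds that differ in one place is available in this set.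

Compound 3 `CN(C)c1cc2[nH]c(C3CCCCC3)nc2cc1NC(=O)OCC(F)(F)F` is not yet measured. It differs from compound 2 by dimethylamino in place of diethylamino on an aromatic carbon, in words: dimethylamino in place of diethylamino on an aromatic carbon. The diethylamino group is kept in compound 2 and the dimethylamino group is present in compound 1, and both of those compounds only reach the limit in this assay. On that basis no step beyond the scatter is expected in this assay, in either direction. The expected step is a step that the limit leaves unreadable from compound 2 to compound 3. Compound 3 is estimated at 150 ug/mL, with a range from 60 ug/mL to 350 ug/mL, and a further limit rather than a number is the likelier outcome.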

Compound 3, half-maximal inhibitory concentration: > 100 ug/mL
Compound 3: a limit, no number; the forecaster's own chance of this, stated with the estimate: 80%; the middle value is on the limit's open side.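

Compound 3 gives a limit and not a number in this assay, so no step can be read from compound 2 to compound 3 or from compound 1 to compound 3, and all three compounds rest at the same limit: the limit of > 100 ug/mL in this assay, at which 3 of the 3 values shown sit. The compounds shown leave open how these three would rank on this read-out, and whether either change shifts it at all.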